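The compounds below may be only part of what the source reports. "The series", "measured", "known", "first", "only" and "open" are said of these compounds alone.

In a functional assay on CHO cells for antagonist activity at prostaglandin E2 receptor EP3 subtype (Homo sapiens), read by cAMP accumulation, with a stated time of 30 min (a lower number here means a stronger inhibitor, a higher number a weaker inhibitor), three compounds have been measured:

Compound 1 `CCC(CC)C(/C=C1\OC(=O)NC1=O)c1ccc(-c2ccc3cccc(F)c3c2)[nH]c1=O`: 23 nM
Compound 2 `O=C1NC(=O)/C(=C/C(c2ccc(-c3ccc4cccc(F)c4c3)[nH]c2=O)C2CC2)O1`: 33 nM
Compound 3 `CC(C)C(/C=C1\OC(=O)NC1=O)c1cc(Cl)c(-c2ccc3cccc(F)c3c2)[nH]c1=O`: 360 nM

Compound 2 holds the second highest of these three numbers. Its nearest neighbour is compound 1: the step of a 1.4-fold higher number from compound 1 to compound 2 (0.16 log units; within the scatter) lies within the scatter, so the two cannot be ranked against each other. Among the compounds with values here, the furthest number is that of compound 3, and the gap between the value of compound 2 and the value of compound 3 lies beyond the scatter; compound 3, however, differs from compound 2 in more than one place, so no single step connects them.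

Compound 4 `O=C1NC(=O)/C(=C/C(c2ccccc2)c2ccc(-c3ccc4cccc(F)c4c3)[nH]c2=O)O1` is not yet measured. It differs from compound 2 in one place: phenyl in place of cyclopropyl on a saturated chain carbon bound to an aromatic carbon and a double-bonded chain carbon. Within the data shown here, the only measured step that touches this carbon is a 1.4-fold higher number from compound 1 to compound 2 (0.16 log units; within the scatter), and it was small: exchanging one saturated group for another there left the number within the scatter. Among the measured compounds shown here, no measured step puts an aromatic group at this position, so the data give no direct guide for a phenyl. Given the small size of a 1.4-fold higher number from compound 1 to compound 2 (0.16 log units; within the scatter), the expected step of a 1.2-fold higher number from compound 2 to compound 4 (0.08 log units; within the scatter) is also small, with a wide margin of uncertainty. Compound 4 is therefore estimated at 40 nM in this assay, within a range from 12 nM to 150 nM.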

Compound 4, half-maximal inhibitory concentration: 190 nM
Compound 4: the middle estimate sits 4.8-fold (0.68 log units) below what was measured, outside the stated range (above it).
By their numbers in this assay, from the lowest: compounds 1 and 2 (each within the scatter of the next); then compounds 4 and 3 (each within the scatter of the next).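

In this assay, the saturated chain carbon bound to an aromatic carbon and a double-bonded chain carbon turns out not to accept every group equally, which the exchange of one saturated group for another could not show. Phenyl in place of cyclopropyl gives a 5.8-fold higher number from compound 2 to compound 4 (0.76 log units; beyond the scatter) and phenyl in place of pentan-3-yl gives an 8.3-fold higher number from compound 1 to compound 4 (0.92 log units; beyond the scatter) as the second step beyond the scatter at this carbon. Compound 1 and compound 2 cannot be ranked against each other, so among these three compounds, the two with saturated groups stand together and compound 4, with the aromatic ring, is the weaker inhibitor. Nothing in the available data gives a reason for this step.

The compounds shown leave open whether the higher number belongs to the aromatic ring itself, or whether a benzyl group, a pyridine ring or a phenyl carrying a methoxy group at this carbon would give the same result. They also leave open whether a saturated six-membered ring such as cyclohexyl would stay with the saturated groups or move towards phenyl.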